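Swapping the sulfonamide heteroaryl on a chromone-based series

The source may hold more compounds than are shown below. What is called first, only, known or untested is meant among the compounds shown, and "the series" means these compounds.

Measured so far:
- Compound 1 `Cc1cc(NS(=O)(=O)c2ccc(NCc3coc4ccccc4c3=O)cc2)no1`: in a functional assay on A549 cells (Homo sapiens) for cytotoxicity, read by sulforhodamine B assay, with a stated time of 72 h (on this read-out lower numbers stand for stronger inhibition and higher numbers for weaker inhibition), compound 1 gives 59700 nM.
- Compound 2 `O=C1/C(=C/c2coc3ccccc3c2=O)N=C(c2ccccc2)N1c1ccc(S(=O)(=O)Nc2nccs2)cc1`: in this assay compound 2 gives 88400 nM.
- Compound 3 `O=C1/C(=C/c2coc3ccccc3c2=O)N=C(c2ccc(Cl)cc2)N1c1ccc(S(=O)(=O)Nc2nccs2)cc1`: in this assay compound 3 gives only > 100000 nM, which is a limit of the assay rather than a number.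

Going by the values given here, compound 3 therefore stands at the weak end of what has been measured; it is the one value sitting at the limit of > 100000 nM in this assay, at which 1 of the 3 values shown sits, and the only measured step, an at least 1.1-fold higher number from compound 2 to compound 3 (0.05 log units; that floor lies within the scatter), reaches it from compound 2 by adding chloro in place of hydrogen on an aromatic carbon.

Compound 4 `Cc1cc(C)nc(NS(=O)(=O)c2ccc(N3C(=O)/C(=C/c4coc5ccccc5c4=O)N=C3c3ccc(Cl)cc3)cc2)n1` keeps the core of compound 3 and changes only the group on the sulfonamide nitrogen: 4,6-dimethylpyrimidin-2-yl in place of 1,3-thiazol-2-yl on a sulfonamide nitrogen. Among the compounds with values here, no measured step touches this position. Compound 1 carries a different sulfonamide heteroaryl, but it differs from compounds 2 and 3 in several places at once, so its value says nothing direct about this swap. With no guidance from the measured steps, the expectation for a number no higher from compound 3 to compound 4 (the limit leaves the size open) is a step no larger than the scatter, in no particular direction. Compound 4 is therefore expected at about 100000 nM, within 40000 nM to 250000 nM, with a good chance that this assay again reports only a limit.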

Compound 4, half-maximal inhibitory concentration: 52600 nM
The estimate for compound 4 lay 1.9-fold (0.28 log units) above the measured number; measured number inside the range.
By their numbers in this assay, from the lowest: compounds 4, 1 and 2 (each within the scatter of the next). At a limit, above all of these: compound 3.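

In this assay, going by these compounds alone, this is the first measured step at the sulfonamide nitrogen: 4,6-dimethylpyrimidin-2-yl in place of 1,3-thiazol-2-yl gives an at least 1.9-fold lower number from compound 3 to compound 4 (0.27 log units; that floor lies within the scatter). Compound 4 returns an actual number, which shows that a change at this position alone can bring the chlorinated compound within the readable range of the assay. How large the step really is remains unknown because the value for compound 3 is a limit rather than a number: the limit of > 100000 nM in this assay, at which 1 of the 4 values shown sits.

Going by these compounds, it remains open whether the same swap would have a similar result with hydrogen in place of the chloro, as in compound 2. Also open, on these data alone, is what a pyrimidin-2-yl without its two methyl groups, or an acetyl group, would give on this nitrogen.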